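A few compounds are considered here, and "the series" means these few. Any claim that something is new, unique, unknown or untested is made for them only; others in the source may bear on it.

Values in a functional assay on KB cells (Homo sapiens) for cytotoxicity, read by resazurin assay, with a stated time of 3 days; a higher number here means a weaker inhibitor, a lower number a stronger inhibitor:

- compound 1 `CCCC(C)C(=O)NCC(C)(C)CC1=C(O)C(=O)c2ccccc2C1=O`: 47100 nM
- compound 2 `CCCCCC(=O)NCC(C)(C)CC1=C(O)C(=O)c2ccccc2C1=O`: 40200 nM
- compound 3 `CCCC(C)C(=O)OCC(C)(C)CC1=C(O)C(=O)c2ccccc2C1=O`: 1760 nM

Compound 3 has the lowest number of the three, which makes it the strongest inhibitor here. The measured steps to it are a 27-fold lower number from compound 1 to compound 3 (1.43 log units; beyond the scatter) and a 23-fold lower number from compound 2 to compound 3 (1.36 log units; beyond the scatter). Both replace an amino link with an oxy link, and that link stays the same in the next compound.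

Compound 4 `CCCCCCC(=O)OCC(C)(C)CC1=C(O)C(=O)c2ccccc2C1=O` keeps the oxy link of compound 3 and changes only the chain: hexyl in place of 1-methylbutyl on a carbonyl carbon. In words, this is hexyl in place of 1-methylbutyl on a carbonyl carbon.

The closest guide is the pentyl for 1-methylbutyl swap, a 1.2-fold lower number from compound 1 to compound 2 (0.07 log units; within the scatter). That swap was measured with the amino link and with pentyl rather than hexyl, so it is only a loose guide. Even so, it points to no expected change in this assay beyond the scatter, in either direction. The estimated change is a 1.0-fold higher number from compound 3 to compound 4 (0.01 log units; within the scatter). For compound 4 the expected value is 1800 nM, with an estimated range of 700 nM to 4500 nM.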

Compound 4, half-maximal inhibitory concentration: 14400 nM
Compound 4: middle estimate off by 8.0-fold (0.90 log units), on the low side, and the stated range ends below it.
By their numbers in this assay, from the lowest: compound 3; then compound 4; then compounds 2 and 1 (each within the scatter of the next).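

With the oxy link in place, the chain on the carbonyl carbon clearly matters in this assay: hexyl in place of 1-methylbutyl gives an 8.2-fold higher number from compound 3 to compound 4 (0.91 log units; beyond the scatter), whereas pentyl for 1-methylbutyl with the amino link gave only a 1.2-fold lower number from compound 1 to compound 2 (0.07 log units; within the scatter), although that swap used a different chain. The gain from the oxy link also depends on the chain, since a 2.8-fold lower number from compound 2 to compound 4 (0.45 log units; beyond the scatter) and a 3.3-fold lower number from compound 1 to compound 4 (0.51 log units; beyond the scatter) are both smaller than the steps to compound 3. No measurement here accounts for this difference.

As far as these compounds go, what stays open is whether the branching of 1-methylbutyl or the extra carbon of hexyl matters more, and pentyl on the oxy link would separate the two. Also open, from the compounds shown here alone, is how a longer chain such as octyl would behave with either link.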